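This account rests on a few compounds, and the source may have more. Where it says the series, first, only, none or still open, it means among the compounds named here.

In a functional assay on HCT-116 cells (Homo sapiens) for cytotoxicity, read by MTT assay, with a stated time of 48 h (a lower number here means a stronger inhibitor of growth, a higher number a weaker inhibitor of growth), compound 1 `Fc1ccccc1-c1nc2cc(Cl)c(Cl)cc2[nH]1` gives 56500 nM and compound 2 `CCn1c(C(F)(F)F)nc2cc(Cl)c(Cl)cc21` gives 95300 nM as its value, so the two stand within the usual scatter of each other. Compound 3 `C=CCn1c(C(F)(F)F)nc2cc(Cl)c(Cl)cc21` is still unmeasured. It differs from compound 2 in one place vinyl in place of methyl on a saturated chain carbon bound to an aromatic nitrogen and this turns ethyl to allyl. Within the data shown here, no measured pair shows what this change does, so no shift beyond the scatter is expected. The expected step is a 1.2-fold lower number from compound 2 to compound 3 (0.08 log units; within the scatter) and it stays within that scatter. Estimated for compound 3 is 80000 nM in the middle of a range from 38000 nM to 150000 nM at its top.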

Compound 3, concentration for 50% growth inhibition: 89200 nM
Compound 3: the middle estimate sits 1.1-fold (0.05 log units) below what was measured; low and high end bracket the measured number.
By their numbers in this assay, from the lowest: compounds 1, 3 and 2 (each within the scatter of the next).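

Vinyl in place of methyl on a saturated chain carbon bound to an aromatic nitrogen gives a 1.1-fold lower number from compound 2 to compound 3 (0.03 log units; within the scatter) in this assay, the first reading of any change at this position. So ethyl and allyl cannot be told apart here, and the added double bond brings no shift beyond the scatter. Going by these compounds, whether a longer chain or an amine at this place would move the number beyond the scatter stays open, and a single pair cannot show how other changes here behave. Nothing available explains this result.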